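The source may hold more compounds than are shown below. What is called first, only, known or untested is meant among the compounds shown, and "the series" means these compounds.

Measured compounds:

Compound 1, `CCN(CC)c1cc2[nH]c(C3CCCCC3)nc2cc1NC(=O)c1cnccn1`. In an ADME assay on Vero cells (Chlorocebus sabaeus) for cytotoxicity, read by resazurin assay, with a stated time of 3 days (a higher number here means a weaker inhibitor, a lower number a stronger inhibitor), compound 1 gives > 100 ug/mL, which is a limit of the assay rather than a number.
Compound 2, `CCN(CC)c1cc2[nH]c(C3CCCCC3)nc2cc1NC(=O)c1ccc(OC(F)(F)F)cc1`. In this assay compound 2 gives > 100 ug/mL, again a limit.
Compound 3, `CCOc1ccc(C(=O)Nc2cc3nc(C4CCCCC4)[nH]c3cc2N(CC)CC)cc1`. In this assay compound 3 gives > 100 ug/mL, also a limit.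

Compound 3 therefore stands where every measured compound stands: at the limit, as summarised by the limit of > 100 ug/mL in this assay, at which 3 of the 3 values shown sit. None of the steps among the three can be sized. The change a step that the two limits leave unreadable from compound 1 to compound 2, the change a step that the two limits leave unreadable from compound 1 to compound 3 and the change a step that the two limits leave unreadable from compound 2 to compound 3 all run between two limits, so nothing is known about how large any of them is.

The next compound, compound 4, is `CCc1ccc(C(=O)Nc2cc3nc(C4CCCCC4)[nH]c3cc2N(CC)CC)cc1`. It differs from compound 3 in one place: ethyl in place of ethoxy on an aromatic carbon. The closest comparison among the measured compounds is the step from compound 2 to compound 3, which also swaps a group on that oxygen, and it too is unreadable. With three limits and no readable step, the expectation is simply that compound 4 stays at the limit, so the expected step from compound 3 is a number no higher from compound 3 to compound 4 (the limit leaves the size open), nothing beyond the scatter. The estimated value for compound 4 in this assay is 100 ug/mL, expected to lie between 50 ug/mL and 200 ug/mL.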

Compound 4, half-maximal inhibitory concentration: > 100 ug/mL
Compound 4 gave a limit, no number; the forecaster's own chance of this, stated with the estimate: 85%; the middle value lies on the limit itself.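

In this assay compound 4 gives > 100 ug/mL, again a limit and not a number. Its steps to compound 1, compound 2 and compound 3 therefore cannot be read: the limit of > 100 ug/mL in this assay, at which 4 of the 4 values shown sit.

The compounds shown leave open whether swapping among the ethyl, ethoxy, trifluoromethoxy and pyrazin-2-yl groups changes cytotoxicity at all, and by how much.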